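The source may hold more compounds than are shown below. What is called first, only, known or untested is meant among the compounds shown, and "the series" means these compounds.

Two compounds measured in a functional assay on OVCAR-8 cells (Homo sapiens) for inhibition, read by sulforhodamine B assay, with a stated time of 48 h (a lower number here means a stronger inhibitor of growth, a higher number a weaker inhibitor of growth), frame this account. Compound 1, `COc1ccc(-c2[nH]c3ccccc3c2/C=C(\C#N)S(=O)(=O)c2ccccc2)cc1`, gives 1300 nM in this assay. Compound 2, `CCOC(=O)C(=Cc1c(-c2ccccc2)[nH]c2ccccc12)C(=O)OCC`, gives 4100 nM in this assay. Of the two numbers, compound 1 holds the lower one, and the gap between compound 1 and compound 2 lies beyond the usual scatter of repeated measurements, so compound 1 is the stronger inhibitor of growth among the two compounds measured here. Among the measured compounds shown here, no pair of measured compounds differs in only one place, so no single step can be read directly from the data.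

Compound 3, `COc1ccc(-c2[nH]c3ccc(OC)cc3c2/C=C(\C#N)S(=O)(=O)c2ccccc2)cc1`, is the unmeasured compound. It differs from compound 1 by methoxy in place of hydrogen on an aromatic carbon. For the measured compounds named here, no measured pair shows what such a change does in this assay, so any expectation rests on compound 1 alone. The step from compound 1 to compound 3 is expected to be small, a 1.3-fold lower number from compound 1 to compound 3 (0.11 log units; within the scatter), likely within the scatter in either direction. Compound 3 is therefore expected to give about 1000 nM in this assay, with a range from 400 nM to 3000 nM.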

Compound 3, concentration for 50% growth inhibition: 3100 nM
Estimate against measurement, compound 3: 3.1-fold (0.49 log units) below; the measured number lies above the stated range.
By their numbers in this assay, from the lowest: compound 1; then compounds 3 and 2 (each within the scatter of the next).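

Among the compounds shown here, this is the first step in this assay that can be read at a single place, and it shows that the aromatic carbon meta to a fused ring and para to a fused ring does not accept every change without effect: methoxy in place of hydrogen gives a 2.4-fold higher number from compound 1 to compound 3 (0.38 log units; beyond the scatter), a modest step beyond the scatter and toward weaker inhibition of growth. In this one pair, hydrogen at this position holds the lower number, so the added methoxy brings no gain over the unsubstituted carbon of compound 1. No separate measurement bears on why the step runs in this direction.

A single step at a single position cannot show whether the change in number belongs to methoxy specifically or would follow from other groups on the same carbon, such as a fluorine atom, a hydroxyl group or a longer ethoxy chain. The compounds shown also leave open whether methoxy in place of hydrogen would produce a similar step on the core of compound 2, which carries two ethyl ester groups.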